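Adding a Methoxy Group to the Pendant Phenyl Ring

The compounds below may be only part of what the source reports. "The series", "measured", "known", "first", "only" and "open" are said of these compounds alone.

Of the compounds shown here, three sharing one core have been tested in a functional assay on cells (Cancer cell lines, Homo sapiens) for cytotoxicity, read by sulforhodamine B assay, with a stated time of 48 h; on this read-out higher numbers stand for weaker inhibition of growth and lower numbers for stronger inhibition of growth. Compound 1 `COc1ccc(C2CC(c3ccccc3)=NN2C2=NC(=O)/C(=C3\C(=O)Nc4ccccc43)S2)cc1` gives 2020 nM. Compound 2 `COc1ccc(C2=NN(C3=NC(=O)/C(=C4\C(=O)Nc5ccccc54)S3)C(c3ccc(OC)cc3)C2)cc1` gives 81500 nM. Compound 3 `O=C1N=C(N2N=C(c3ccccc3)CC2c2ccc(Cl)cc2)S/C1=C1/C(=O)Nc2ccccc21` gives 320 nM, the lowest of the three numbers and therefore the strongest inhibition of growth seen so far; its nearest neighbour is compound 1, while compound 2 stands far above both. Compound 4 `COc1ccc(C2=NN(C3=NC(=O)/C(=C4\C(=O)Nc5ccccc54)S3)C(c3ccc(Cl)cc3)C2)cc1` has not yet been measured. It differs from compound 3 in a single place: methoxy in place of hydrogen on an aromatic carbon. The very same change has been observed once already within this set, and the outcome was clear: a 40-fold higher number from compound 1 to compound 2 (1.61 log units; beyond the scatter). That step was large and well beyond the usual scatter, so a step in the same direction and of comparable size is expected here, even though a single example is slender support. The other measured step, a 6.3-fold lower number from compound 1 to compound 3 (0.80 log units; beyond the scatter), concerns a different group and does not bear directly on the present change. Compound 4 is accordingly expected to give about 12000 nM, with a likely range from 3000 nM to 50000 nM. The estimated step, a 38-fold higher number from compound 3 to compound 4 (1.57 log units; beyond the scatter), is expected to echo the earlier one.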

Compound 4, concentration for 50% growth inhibition: 100000 nM
The estimate for compound 4 lay 8.3-fold (0.92 log units) below the measured number, and the stated range ends below it.
By their numbers in this assay, from the lowest: compound 3; then compound 1; then compounds 2 and 4 (each within the scatter of the next).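

In this assay, the change from phenyl to 4-methoxyphenyl again weakens inhibition of growth, a 310-fold higher number from compound 3 to compound 4 (2.49 log units; beyond the scatter), so its direction now holds on two cores, although its size differs between them: the same change on two cores in this assay, a 40-fold higher number (1.61 log units; beyond the scatter) from compound 1 to compound 2 and a 310-fold higher number (2.49 log units; beyond the scatter) from compound 3 to compound 4, 7.7-fold (0.89 log units) apart, beyond the scatter of two such steps. For the compounds shown here, the chloro in place of methoxy, which lowered the number when the pendant phenyl ring carried only hydrogen, no longer separates the compounds once the methoxy is present, a 1.2-fold higher number from compound 2 to compound 4 (0.09 log units; within the scatter), and the size of that change therefore depends on what stands at this position: the same change on two cores in this assay, a 6.3-fold lower number (0.80 log units; beyond the scatter) from compound 1 to compound 3 and a 1.2-fold higher number (0.09 log units; within the scatter) from compound 2 to compound 4, 7.7-fold (0.89 log units) apart, beyond the scatter of two such steps. The two changes thus do not simply add up, and with the methoxy in place, the chloro compound loses the advantage seen without it.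

The compounds shown carry only hydrogen or methoxy at this position, so they cannot tell whether an amine, a carboxylic acid or a longer chain such as butoxy would raise the number in the same way. They also leave open why the methoxy has this effect, and whether the dependence between the two changes extends beyond these four compounds.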